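The compounds below may be only part of what the source reports. "The series", "measured", "known", "first", "only" and "open" are said of these compounds alone.

Measured so far:
compound 1, `CCCNNC(=O)c1cnc(N2CCN(Cc3c[nH]c4ccccc34)CC2)nc1` — 570 nM
compound 2, `CCCCCCNNC(=O)c1cccc(NCc2ccccc2)c1` — 8600 nM

In an assay on isolated protein for inhibition of histone deacetylase 11 (Homo sapiens), read by fluorescence, with a stated time of 10 min (a higher number here means a weaker inhibitor, a lower number a stronger inhibitor), compound 1 gives the lower of the two numbers shown; compound 2 sits far higher, beyond the scatter. Compound 3, `CCCCCCNNC(=O)c1cnc(N2CCN(Cc3c[nH]c4ccccc34)CC2)nc1`, has not been measured. It differs from compound 1 by propyl in place of hydrogen on a saturated chain carbon, three bonds along the chain from an amine nitrogen. Going by the values given here, no step between measured compounds shows what such a chain extension does on this core; compound 2 carries the longer chain but on a different core, so its value cannot be read across. A modest gain is expected, the step from compound 1 to compound 3 being a 2.3-fold lower number from compound 1 to compound 3 (0.36 log units; beyond the scatter). Compound 3 is therefore estimated at 250 nM, with a range of 60 nM to 1500 nM.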

Compound 3, half-maximal inhibitory concentration: 41 nM
Compound 3: the middle estimate sits 6.1-fold (0.79 log units) above what was measured; measured number outside the range, below it.
By their numbers in this assay, from the lowest: compound 3; then compound 1; then compound 2.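

In this assay, going by these compounds alone, this is the first reading of chain length on a single core: going from propyl to hexyl gives a 14-fold lower number from compound 1 to compound 3 (1.14 log units; beyond the scatter) with the rest of the molecule unchanged. Chain length at this place is thus a strong lever on the core of compound 1, which compound 2, on a different core, could not show. Nothing at hand explains the size of this step. Still open, on these data alone, is whether a longer chain such as octyl would lower the number further or raise it again, and whether a hexyl chain ending in an amine or a carboxylic acid would keep the gain.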